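Phenyl for 2-phenylethenyl on the shared core

The source may hold more compounds than are shown below. What is called first, only, known or untested is meant among the compounds shown, and "the series" means these compounds.

Measured in a functional assay on A549 cells (Homo sapiens) for cytotoxicity, read by MTT assay, with a stated time of 72 h (on this read-out higher numbers stand for an effect only at larger amounts of compound and lower numbers for an effect already at smaller amounts), so far:
compound 1 `O=c1cc(Nc2ccccc2)cc(-c2ccccc2)o1` 0.12 uM
compound 2 `CCCCCc1cc(Nc2ccc(OC)cc2)cc(=O)o1` 4.42 uM
compound 3 `COc1ccc(Nc2cc(/C=C/c3ccccc3)oc(=O)c2)cc1` 0.11 uM

Compound 3 lies within the scatter of compound 1 and far from compound 2, as the measured step shows: a 40-fold lower number from compound 2 to compound 3 (1.60 log units; beyond the scatter) at the same place. Compound 4 `COc1ccc(Nc2cc(-c3ccccc3)oc(=O)c2)cc1` carries phenyl in place of 2-phenylethenyl on an aromatic carbon next to the ring oxygen phenyl in place of 2-phenylethenyl on an aromatic carbon and is otherwise unchanged. That large step replaced pentyl, so it bears only indirectly on this swap. Compound 4 shares phenyl at that place with compound 1, which gives 0.12 uM though the two differ elsewhere. In this assay no step beyond the scatter is therefore expected. The expected step is a 1.3-fold higher number from compound 3 to compound 4 (0.10 log units; within the scatter) and a slightly higher number is the likelier direction. Compound 4 is estimated at 0.14 uM with 0.05 uM to 0.45 uM as the likely span of the measurement.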

Compound 4, concentration for half-maximal effect: 0.093 uM
Compound 4: the middle estimate sits 1.5-fold (0.18 log units) above what was measured; the range from low to high includes it.
By their numbers in this assay, from the lowest: compounds 4, 3 and 1 (each within the scatter of the next); then compound 2.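

At the aromatic carbon next to the ring oxygen, phenyl in place of 2-phenylethenyl gives a 1.2-fold lower number from compound 3 to compound 4 (0.07 log units; within the scatter) in this assay so the double bond outside aromatic rings is not required for this level of effect. Phenyl in place of pentyl gives a 48-fold lower number from compound 2 to compound 4 (1.68 log units; beyond the scatter) and thus matches the large step seen with 2-phenylethenyl. Methoxy in place of hydrogen on an aromatic carbon gives a 1.3-fold lower number from compound 1 to compound 4 (0.11 log units; within the scatter) and leaves the number within the scatter.

Going by these compounds, whether an amine, a carboxylic acid or a chain shorter than pentyl at this place would keep this level remains open. Nothing available explains these steps.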